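The source may report more compounds than this note shows. Statements on the series, on what has been measured and on what is new or still open speak of the compounds shown alone.

Measured in a toxicity assay on THP-1 cells (Homo sapiens) for inhibition; on this read-out higher numbers stand for lower toxicity in this test and lower numbers for higher toxicity in this test:
Compound 1, `Cc1ccccc1-c1cnc(NC(=O)c2ccc(F)cc2)n1C`, gives the limit > 50000 nM.
Compound 2, `COc1ccc(-c2cnc(NC(=O)c3cccc(C)c3)n2C)cc1`, gives the limit > 100000 nM.
Compound 3, `Cn1c(-c2ccccc2)cnc1NC(=O)c1cccc(Br)c1`, gives the limit > 50000 nM.

None of the three yields a number in this assay; each stops at a limit. Compound 1 sits at the limit of > 50000 nM in this assay, at which 2 of the 3 values shown sit. Compound 2 sits at the limit of > 100000 nM in this assay, at which 1 of the 3 values shown sits. Compound 4, `COc1ccccc1-c1cnc(NC(=O)c2ccc(F)cc2)n1C`, differs from compound 1 by methoxy in place of methyl on an aromatic carbon. Among the measured compounds shown here, no step between measured compounds is available, so nothing shows how such a change moves this read-out; with every measured compound stopping at a limit, a step of no size beyond the scatter is expected in this assay, neither toward higher nor toward lower toxicity. Compound 4 is therefore expected to give 60000 nM, within 30000 nM to 200000 nM, most likely again as a limit rather than a number. The expected step that the limit leaves unreadable from compound 1 to compound 4 is small.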

Compound 4, half-maximal cytotoxic concentration: > 100000 nM
Compound 4 ended at the assay's limit; the forecaster's own chance of this, stated with the estimate: 85%; middle value at least 1.6-fold (0.22 log units) from the limit.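

Compound 1 and compound 4 both stop at limits in this assay, and no step can be read between them. The compounds shown leave open whether methoxy in place of methyl on an aromatic carbon changes the result in this assay at all.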